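Methyl in Place of Amino, Tested Against Two Backgrounds

The source may hold more compounds than are shown below. What is called first, only, known or untested is meant among the compounds shown, and "the series" means these compounds.

Compound 1 `Cc1ccc2oc(CSc3nnc(C)s3)cc(=O)c2c1`: > 25000 nM in this assay
Compound 2 `Cc1ccc2oc(CSc3nnc(N)s3)cc(=O)c2c1`: > 25000 nM in this assay
Compound 3 `Nc1nnc(SCc2coc3ccccc3c2=O)s1`: 950 nM in this assay

Of the compounds shown here, three have been measured in a functional assay on MDA-MB-435S cells (Homo sapiens) for cytotoxicity, read by MTT assay, with a stated time of 72 h; a lower number here means a stronger inhibitor, a higher number a weaker inhibitor. Compound 1 `Cc1ccc2oc(CSc3nnc(C)s3)cc(=O)c2c1` gives > 25000 nM, which is a limit of the assay and not a number. Compound 2 `Cc1ccc2oc(CSc3nnc(N)s3)cc(=O)c2c1` likewise gives > 25000 nM, again a limit. Within the data shown here, compound 3 `Nc1nnc(SCc2coc3ccccc3c2=O)s1` gives 950 nM, the only real number among the three.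

Compound 2 and compound 1 differ by one change, (methyl in place of amino on an aromatic carbon). Because both values sit at the limit of > 25000 nM in this assay, at which 2 of the 3 values shown sit, the step that the two limits leave unreadable from compound 2 to compound 1 cannot be read; its size is hidden by the two limits. Compound 3 shares the 5-amino-1,3,4-thiadiazol-2-yl group with compound 2, but the difference between their two cores is not broken down here.

Compound 4 `Cc1nnc(SCc2coc3ccccc3c2=O)s1` has not yet been measured. It differs from compound 3 by methyl in place of amino on an aromatic carbon, the same change as from compound 2 to compound 1, at a place described in the same words. Since the measured instance of this change is unreadable, the expectation for compound 4 rests on compound 3 alone, whose value of 950 nM is the only anchor. The change removes one hydrogen-bond donor and one acceptor; with no readable precedent, compound 4 is estimated to land at 2500 nM, between 600 nM and 15000 nM. The step expected from compound 3 to compound 4 is a 2.6-fold higher number from compound 3 to compound 4 (0.42 log units; beyond the scatter), a guess leaning toward a modest loss, widely bracketed.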

Compound 4, half-maximal inhibitory concentration: 630 nM
For compound 4 the middle estimate is 4.0-fold (0.60 log units) above the measured one; low and high end bracket the measured number.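

In this assay, methyl in place of amino on the core of compound 3 gives a 1.5-fold lower number from compound 3 to compound 4 (0.18 log units; within the scatter), so on this core the change from 5-amino-1,3,4-thiadiazol-2-yl to 5-methyl-1,3,4-thiadiazol-2-yl gives two values that cannot be told apart. The same change on the core of compound 2 cannot be read, because compound 2 and compound 1 both stand at a limit of the assay rather than at a number: the limit of > 25000 nM in this assay, at which 2 of the 4 values shown sit. This leaves a single readable instance of the change, which shows that amino is not needed for the activity seen on the core of compound 3, but does not show that the change would behave in the same way on the core of compound 2, or that the two cores respond alike.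

The compounds shown leave open how a longer chain such as propyl, a carboxylic acid or a dimethylamino group would read in the place of the amino on the core of compound 3. They also leave open whether the close agreement of compound 3 and compound 4 would hold on any further core that gives readable numbers.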